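Swapping a methyl for bromo on a shared core

The source may report more compounds than this note shows. Statements on the series, on what has been measured and on what is new or still open speak of the compounds shown alone.

Compound 1 `Cc1cc(C(=O)c2ccccc2)ccc1OCC(=O)Nc1nc(-c2ccccc2)cs1`: 24500 nM
Compound 2 `Cc1cc(C(=O)c2ccc(F)cc2)ccc1OCC(=O)Nc1nc(-c2ccccc2)cs1`: 38600 nM
Compound 3 `Cc1cc(C(=O)c2ccccc2)cc(C)c1OCC(=O)Nc1nc(-c2ccccc2)cs1`: 23400 nM

In a functional assay on Ehrlich cells (Mus musculus) for cytotoxicity, read by LDH release, with a stated time of 48 h (on this read-out higher numbers stand for weaker inhibition and lower numbers for stronger inhibition), compound 1 gives 24500 nM and stands second highest of the three numbers; its nearest neighbour is compound 3, its furthest compound 2. Compound 4 `O=C(COc1ccc(C(=O)c2ccccc2)cc1Br)Nc1nc(-c2ccccc2)cs1` is not yet measured. It differs from compound 1 in one place: bromo in place of methyl on an aromatic carbon. Two measured steps offer guidance, both of them single changes of a small group on an aromatic carbon of the shared core. The step of a 1.6-fold higher number from compound 1 to compound 2 (0.20 log units; within the scatter) and the step of a 1.0-fold lower number from compound 1 to compound 3 (0.02 log units; within the scatter) each stayed within the scatter. Within the data shown here, no measured step exchanges a methyl for a bromo directly, so the expectation rests on these two small changes. Compound 4 is therefore expected to show no step beyond the scatter, a change of a 1.0-fold higher number from compound 1 to compound 4 (0.01 log units; within the scatter). The estimate for compound 4 is 25000 nM, in the range 12000 nM to 50000 nM.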

Compound 4, half-maximal inhibitory concentration: 46400 nM
Compound 4: middle estimate off by 1.9-fold (0.27 log units), on the low side, within the range that was stated.
By their numbers in this assay, from the lowest: compounds 3, 1, 2 and 4 (each within the scatter of the next).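

Compound 4 is the only one shown with a change at this carbon, ortho to a large group and meta to a benzoyl group. In this assay, bromo in place of methyl gives a 1.9-fold higher number from compound 1 to compound 4 (0.28 log units; within the scatter), so this exchange at this position produces no change that can be told from the scatter. No measurement shown here bears on this result. Still open, going by these compounds, is whether an amine or a carboxylic acid on this same carbon would move the number beyond the scatter.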